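Aryl Swap on an Oxadiazole Thioether: Cytotoxicity Outlook

A few compounds are considered here, and "the series" means these few. Any claim that something is new, unique, unknown or untested is made for them only; others in the source may bear on it.

Compounds measured so far:
compound 1, `Cc1ccc(-c2nnc(SC3=CS(=O)(=O)c4ccccc43)o2)cc1`, 3000 nM
compound 2, `COc1cccc(-c2nnc(SC3=CS(=O)(=O)c4ccccc43)o2)c1`, 3000 nM
compound 3, `O=S1(=O)C=C(Sc2nnc(-c3cccc(Cl)c3)o2)c2ccccc21`, 6000 nM

In an ADME assay on HEK293 cells (Homo sapiens) for cytotoxicity, read by fluorescence and resazurin assay, with a stated time of 24 h (on this read-out higher numbers stand for lower toxicity in this test and lower numbers for higher toxicity in this test), compound 1 gives 3000 nM, level with compound 2 and together with it the lowest of the three numbers, though every gap among these compounds lies within the scatter. The step of no change at the digits printed from compound 1 to compound 2 (within the scatter) and the step of a 2.0-fold higher number from compound 1 to compound 3 (0.30 log units; within the scatter) both stay within the scatter, as does a 2.0-fold higher number from compound 2 to compound 3 (0.30 log units; within the scatter).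

Compound 4, `O=S1(=O)C=C(Sc2nnc(-c3ccccn3)o2)c2ccccc21`, is not yet measured. Its change from compound 1 is pyridin-2-yl in place of 4-methylphenyl on an aromatic carbon. Among the compounds with values here, no measured step replaces the whole aromatic group with a pyridin-2-yl, so the measured steps bear on it only indirectly: each of them alters the aryl group attached to the shared core and none of them moves the number beyond the scatter. On that basis no step beyond the scatter is expected in this assay.

Compound 4 is therefore estimated at 3500 nM, with a range from 1500 nM to 8000 nM, which means an expected step of a 1.2-fold higher number from compound 1 to compound 4 (0.07 log units; within the scatter).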

Compound 4, half-maximal cytotoxic concentration: 5000 nM
Compound 4: middle estimate off by 1.4-fold (0.15 log units), on the low side; low and high end bracket the measured number.
By their numbers in this assay, from the lowest: compounds 1, 2, 4 and 3 (each within the scatter of the next).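

Pyridin-2-yl is the only group among the four compounds with a hetero atom in the six-membered aromatic ring, and in this assay it shows a 1.7-fold higher number from compound 1 to compound 4 (0.22 log units; within the scatter), a 1.7-fold higher number from compound 2 to compound 4 (0.22 log units; within the scatter) and a 1.2-fold lower number from compound 3 to compound 4 (0.08 log units; within the scatter). At this aromatic carbon of the five-membered aromatic ring, a ring of carbon only can therefore give way to a ring holding one nitrogen with no step beyond the scatter, and the four compounds remain unseparated. Nothing available speaks to the reason for this result.

The compounds shown leave open whether a carboxylic acid or an amine on the six-membered ring, or a saturated ring such as piperidine in its place, would move the number beyond the scatter. From the compounds shown here alone, all four also keep the shared core and its sulfur link unchanged, so how changes there would read remains open.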